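From Hydroxyalkynyl to Hydroxyalkenyl on the Aryl Ring

The source may report more compounds than this note shows. Statements on the series, on what has been measured and on what is new or still open speak of the compounds shown alone.

Of the compounds shown here, three sharing one core have been measured in an assay on isolated protein for binding affinity to vitamin D3 receptor (Homo sapiens), read by fluorescence polarization, tested at 1 uM; a lower number here means less inhibition, a higher number more inhibition at the concentration tested (going by the name of the read-out). Compound 1 `CCN(CC)CCNC(=O)C1CC(C(CC)(CC)c2ccc(C#CC(C)(C)O)c(C)c2)=CN1CC` gives 56.3% in this assay, the second highest of the three numbers. Compound 2 `CCN(CC)CCNC(=O)C1CC=C(C(CC)(CC)c2ccc(C#CC(C)(O)CC)c(C)c2)N1CC` gives 63.4% and compound 3 `CCN(CC)CCNC(=O)C1CC=C(C(CC)(CC)c2ccc(C#CC(O)C3CCCC3)c(C)c2)N1CC` gives 47.9%. Compound 1 stands within the scatter of both, so no order among them can be read from these values. Among the compounds with values here, the only step between compounds that differ in one place runs a number 15.5 percentage points lower from compound 2 to compound 3 (beyond the scatter).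

Compound 4 `CCN(CC)CCNC(=O)C1CC(C(CC)(CC)c2ccc(/C=C/C(O)(CC)CC)c(C)c2)=CN1CC` has not yet been measured. It differs from compound 1 as follows: a group of 8 heavy atoms (7 carbon, 1 oxygen; no ring) in place of a group of 6 heavy atoms (5 carbon, 1 oxygen; no ring), on an aromatic carbon The 3-hydroxy-3-methylbut-1-yn-1-yl group, with its triple bond outside aromatic rings, is replaced by a group with a double bond outside aromatic rings, keeping one hydrogen-bond donor and one hydrogen-bond acceptor.

Within the data shown here, no measured step changes the triple bond itself. The step from compound 2 to compound 3 altered only the alcohol-bearing end of that arm and was modest. Compound 1 and compound 2, which differ at the alcohol and elsewhere, are within the scatter of each other. On that basis the change to compound 4 is expected to give a step of about a number 2.3 percentage points lower from compound 1 to compound 4 (within the scatter), not beyond the scatter in either direction. Compound 4 is therefore estimated at 54%, within a range from 34% to 74%.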

Compound 4, a percentage reported as inhibition, at one concentration (the size of the read-out at that concentration, not a potency): 65.5%
The estimate for compound 4 lay 11.5 percentage points below the measured number, within the range that was stated.
By their numbers in this assay, from the lowest: compounds 3, 1, 2 and 4 (each within the scatter of the next, the first and the last beyond it).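

In this assay, replacing the 3-hydroxy-3-methylbut-1-yn-1-yl group on the aromatic carbon with the 8-heavy-atom group that carries a double bond gives a number 9.2 percentage points higher from compound 1 to compound 4 (within the scatter). Within the data shown here, every earlier compound kept a triple bond in this arm, so this is the first sign that the arm need not contain one for the number to stay within the scatter of compound 1, even when the group also grows from 6 heavy atoms to 8. The two changes arrive together and their separate contributions cannot be read from this step, and no available evidence explains why the number holds across the change.

The compounds shown leave open what the double bond and the added carbons each contribute, since none pairs the triple bond with the alcohol end of compound 4, or the double bond with the alcohol end of compound 1. They also leave open whether a fully saturated chain in place of the double bond, or an amine or a carboxylic acid in place of the hydroxyl, would keep the number in the same region.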